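A few compounds are considered here, and "the series" means these few. Any claim that something is new, unique, unknown or untested is made for them only; others in the source may bear on it.

Among the compounds with values here, in an ADME assay on BaF3 cells (Mus musculus) for inhibition, read by CellTiter-Glo, with a stated time of 72 h (a lower number here means a stronger inhibitor of growth, a higher number a weaker inhibitor of growth), compound 1 `Cc1ccc(NC(=O)c2cccc(C(F)(F)F)c2)cc1N1Cc2cnc(NC3CCCCC3)nc2N(C)C1=O` gives 5220 nM, the only exact number so far. Compound 2 `Cc1ccc(Nc2ncc3c(n2)N(C)C(=O)N(c2cc(NC(=O)c4cc(-n5cnc(C)c5)cc(C(F)(F)F)c4)ccc2C)C3)cn1` is reported only as a limit, > 5000 nM. Compound 3 `Cc1ccc(NC(=O)c2cccc(C(F)(F)F)c2)cc1N1Cc2cnc(NCCO)nc2N(C)C1=O` keeps the core of compound 1 and carries 2-hydroxyethyl in place of cyclohexyl on a nitrogen on an aromatic ring. Within the data shown here, no measured pair shows what such a change does in this assay, so no step beyond the scatter is expected in either direction, and a reported limit is quite possible. The expected change is a 1.1-fold higher number from compound 1 to compound 3 (0.02 log units; within the scatter). The estimate for compound 3 is 5500 nM, with an expected range of 2500 nM to 12000 nM.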

Compound 3, concentration for 50% growth inhibition: 3290 nM
For compound 3 the middle estimate is 1.7-fold (0.22 log units) above the measured one, and the stated range covers the measured number.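

In this assay, within the data shown here, the only measured pair at this position gives a 1.6-fold lower number from compound 1 to compound 3 (0.20 log units; within the scatter), so 2-hydroxyethyl in place of cyclohexyl on a nitrogen on an aromatic ring leaves the reading within the scatter. A group with no ring and one with a ring of carbon only thus read alike here. Compound 2 is known only as a limit, and that limit lies close to these readings: the limit of > 5000 nM in this assay, at which 1 of the 3 values shown sits.

Going by these compounds, whether an amine, a carboxylic acid or a longer chain on this nitrogen would move the number beyond the scatter stays open. So does whether this change would read the same on a compound with a much lower number.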